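Cyclohexyl to 4-chlorophenyl on the ring amide nitrogen

A few compounds are considered here, and "the series" means these few. Any claim that something is new, unique, unknown or untested is made for them only; others in the source may bear on it.

Measured so far:
Compound 1, `O=C1COc2ccc(-c3cnc(Cl)c(NS(=O)(=O)c4ccc(F)cc4)c3)cc2N1C1CCCCC1`: > 40000 nM
Compound 2, `COc1ccc(N2C(=O)COc3ccc(-c4cnc(Cl)c(NS(=O)(=O)c5ccc(F)cc5)c4)cc32)cc1`: 30100 nM
Compound 3, `COc1ncc(-c2ccc3c(c2)N(C2CCCCC2)C(=O)CO3)cc1NS(=O)(=O)c1ccc(F)cc1`: > 40000 nM

In a functional assay on HCT-116 cells (Homo sapiens) for antiproliferative activity, read by MTT assay, with a stated time of 72 h (a lower number here means a stronger inhibitor, a higher number a weaker inhibitor), compound 3 is reported only as the limit > 40000 nM, so its true value is not known. The same holds for compound 1, whose result in this assay is the limit > 40000 nM. Compound 2 gives a number, 30100 nM, and the step of an at least 1.3-fold lower number from compound 1 to compound 2 (0.12 log units; that floor lies within the scatter) is therefore readable only as a floor. The step that the two limits leave unreadable from compound 1 to compound 3 cannot be read at all, because of the limit of > 40000 nM in this assay, at which 2 of the 3 values shown sit.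

Compound 4, `COc1ncc(-c2ccc3c(c2)N(c2ccc(Cl)cc2)C(=O)CO3)cc1NS(=O)(=O)c1ccc(F)cc1`, has not yet been measured. Its change from compound 3 is 4-chlorophenyl in place of cyclohexyl on an amide-type nitrogen in a ring. For the measured compounds named here, the only measured step that bears on it is the one from compound 1 to compound 2, where a 4-methoxyphenyl in place of cyclohexyl on the amide-type nitrogen in a ring gave an at least 1.3-fold lower number from compound 1 to compound 2 (0.12 log units; that floor lies within the scatter), a floor that sits within the scatter. Compound 4 is therefore expected to behave much like compound 3, and the estimated step of an at least 1.1-fold lower number from compound 3 to compound 4 (0.05 log units; that floor lies within the scatter) stays within the scatter or just beyond it toward a lower number. The estimate for compound 4 in this assay is 35000 nM, with a range from 15000 nM to 80000 nM.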

Compound 4, half-maximal inhibitory concentration: 19200 nM
For compound 4 the middle estimate is 1.8-fold (0.26 log units) above the measured one, and the stated range covers the measured number.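

In this assay, for the compounds shown here, the exchange of cyclohexyl for 4-chlorophenyl on the amide-type nitrogen in a ring gives an at least 2.0-fold lower number from compound 3 to compound 4 (0.31 log units; beyond the scatter) and so provides the first step at this position that is printed as beyond the scatter, whereas the earlier step to a 4-methoxyphenyl group did not pass it. Compound 3 is reported only as the limit > 40000 nM and is not a number. From the compounds shown here alone, the printed step is therefore a floor, and its true size stays unknown, because the starting point of the step sits at a limit: the limit of > 40000 nM in this assay, at which 2 of the 4 values shown sit.

The compounds shown leave open whether 4-chlorophenyl would bring a similar step with chloro in place of methoxy on the aromatic carbon, since compound 2 and compound 4 differ in more than one place and cannot be set against each other. They also leave open how a saturated ring carrying an amine, a phenyl ring carrying a carboxylic acid or a longer alkyl chain would fare on the same nitrogen.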